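The source may hold more compounds than are shown below. What is called first, only, known or untested is meant among the compounds shown, and "the series" means these compounds.

Measured compounds:
- compound 1 `CCCCCCCCCCCSC(=S)C1=C(Nc2ccc(Cl)cc2Cl)CC(C)(C)CC1=O` — in a functional assay on cells (blood, Homo sapiens) for inhibition, read by chemiluminescence, with a stated time of 30 min (a higher number here means a weaker inhibitor, a lower number a stronger inhibitor), compound 1 gives > 100 ug/mL, a limit of the assay.
- compound 2 `CC(=O)OC[C@H]1O[C@@H](SC(=S)C2=C(Nc3ccc(Cl)cc3Cl)CC(C)(C)CC2=O)[C@H](OC(C)=O)[C@@H](OC(C)=O)[C@@H]1OC(C)=O` — in this assay compound 2 gives > 100 ug/mL, a limit of the assay.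
- compound 3 `CCCCCCCCCCCSC(=S)C1=C(Nc2ccc(Cl)cc2)CC(C)(C)CC1=O` — in this assay compound 3 gives > 100 ug/mL, a limit of the assay.

Compound 4 `CC(=O)OC[C@H]1O[C@@H](SC(=S)C2=C(Nc3ccc(Cl)cc3)CC(C)(C)CC2=O)[C@H](OC(C)=O)[C@@H](OC(C)=O)[C@@H]1OC(C)=O` is not yet measured. It differs from compound 2 by hydrogen in place of chloro on an aromatic carbon. The same change, (hydrogen in place of chloro on an aromatic carbon), separates compound 1 from compound 3, and its step there, a step that the two limits leave unreadable from compound 1 to compound 3, is not readable because of the limit of > 100 ug/mL in this assay, at which 3 of the 3 values shown sit. The difference between the cores of compound 1 and compound 2 is not broken down here. With every measured value sitting at a limit, no size can be read for this change, and the expectation rests on the limit of > 100 ug/mL in this assay, at which 3 of the 3 values shown sit, alone. The expected step that the limit leaves unreadable from compound 2 to compound 4 is therefore one that stays at the limit. Compound 4 is estimated at 150 ug/mL.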

Compound 4, half-maximal inhibitory concentration: 90 ug/mL
Beside the measured number, compound 4's estimate is 1.7-fold (0.22 log units) above it, outside the stated range (below it).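

In this assay, hydrogen in place of chloro on an aromatic carbon gives an at least 1.1-fold lower number from compound 2 to compound 4 (0.04 log units; that floor lies within the scatter). Compound 2 gives > 100 ug/mL, a limit of the assay, so the true size of this step stays open and no real change is shown. The same change on the core of compound 1 cannot be read, so nothing shows whether a step of any size carries from one core to the other: the limit of > 100 ug/mL in this assay, at which 3 of the 4 values shown sit.

At this place, only chloro and hydrogen are compared, on the (2,4-dichlorophenyl)amino and (4-chlorophenyl)amino groups. Going by these compounds, whether an amine or a carboxylic acid on the same aromatic ring would give a readable value in this assay remains open.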